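Methyl in Place of Trifluoromethyl on Two Related Scaffolds

The source may hold more compounds than are shown below. What is called first, only, known or untested is meant among the compounds shown, and "the series" means these compounds.

Compound 1 `NC(=O)c1c(NC(=O)c2ccccc2Br)sc2c1CCN(C(=S)Nc1ccccc1C(F)(F)F)C2` gives 27400 nM in a functional assay on HL-60 cells (Homo sapiens) for antiproliferative activity, with a stated time of 24 h; a lower number here means a stronger inhibitor, a higher number a weaker inhibitor.
Compound 2 `Cc1ccccc1NC(=S)N1CCc2c(sc(NC(=O)c3ccccc3Br)c2C(N)=O)C1` gives > 50000 nM in this assay, which is a limit of the assay rather than a number.
Compound 3 `NC(=O)c1c(NC(=O)c2ccccc2C(F)(F)F)sc2c1CCN(C(=S)Nc1ccccc1Br)C2` gives 25500 nM in this assay.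

Compound 1 and compound 3 are built from the same atoms joined differently; the difference between the two cores is not broken down here. The change methyl in place of trifluoromethyl on an aromatic carbon produced an at least 1.8-fold higher number from compound 1 to compound 2 (0.26 log units; that floor lies within the scatter), with compound 2 sitting at the limit of > 50000 nM in this assay, at which 1 of the 3 values shown sits. Compound 4 `Cc1ccccc1C(=O)Nc1sc2c(c1C(N)=O)CCN(C(=S)Nc1ccccc1Br)C2` carries the same change, (methyl in place of trifluoromethyl on an aromatic carbon), on the core of compound 3. Since compound 1 showed an at least 1.8-fold higher number from compound 1 to compound 2 (0.26 log units; that floor lies within the scatter), a step of a 1.8-fold higher number from compound 3 to compound 4 (0.25 log units; within the scatter) is expected from compound 3 to compound 4, with a real chance that only a limit is reported. Compound 4 is therefore estimated at 45000 nM, between 18000 nM and 110000 nM.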

Compound 4, half-maximal inhibitory concentration: 45200 nM
For compound 4 the middle estimate is 1.0-fold (0.00 log units) below the measured one, within the range that was stated.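

On the core of compound 3, methyl in place of trifluoromethyl on an aromatic carbon gave a 1.8-fold higher number from compound 3 to compound 4 (0.25 log units; within the scatter) in this assay, so this pair shows no clear effect of the change on that core. As far as these compounds go, the value of compound 2, > 50000 nM, is a limit of the assay and not a number, so the size of the step on the core of compound 1 remains unknown. The two cores therefore show no firm evidence either that the change carries over unchanged or that it depends on the core: the same change on two cores in this assay, an at least 1.8-fold higher number (0.26 log units; that floor lies within the scatter) from compound 1 to compound 2 and a 1.8-fold higher number (0.25 log units; within the scatter) from compound 3 to compound 4; the limit leaves it open whether they differ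

The compounds shown leave open how a methoxy group, a chlorine atom or an amine in the same place would read in this assay. They also leave open whether the change would behave alike on any further core.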